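A few compounds are considered here, and "the series" means these few. Any claim that something is new, unique, unknown or untested is made for them only; others in the source may bear on it.

The series shares one core, shown in compound 1 `COc1ccc(-c2cnc3nc(N)nc(N4CCN(C(=O)NCc5ccccc5)CC4)c3n2)cc1OC`, whose piperazine-linked carbonyl carries different groups. In a functional assay on cells (T-cell, Homo sapiens) for inhibition (on this read-out higher numbers stand for weaker inhibition and lower numbers for stronger inhibition), compound 1 gives 18 nM. Compound 2 `COc1ccc(-c2cnc3nc(N)nc(N4CCN(C(=O)Nc5ccc(C)cc5)CC4)c3n2)cc1OC` gives 0.8 nM in this assay, and compound 3 `COc1ccc(-c2cnc3nc(N)nc(N4CCN(C(=O)COc5ccccc5)CC4)c3n2)cc1OC` gives 4 nM. Among the three measured numbers compound 3 stands second highest: compound 1 sits above it by a 4.5-fold lower number from compound 1 to compound 3 (0.65 log units; beyond the scatter) reversed, while compound 2 sits below it by a 5.0-fold higher number from compound 2 to compound 3 (0.70 log units; beyond the scatter) reversed.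

Compound 4 `COc1ccc(-c2cnc3nc(N)nc(N4CCN(C(=O)c5ccccc5)CC4)c3n2)cc1OC` differs from compound 3 only at the carbonyl carbon: phenyl in place of phenoxymethyl on a carbonyl carbon.

Among the measured compounds shown here, two measured steps bear on this position. The change from benzylamino to phenoxymethyl gave a 4.5-fold lower number from compound 1 to compound 3 (0.65 log units; beyond the scatter), and the change from (4-methylphenyl)amino to phenoxymethyl gave a 5.0-fold higher number from compound 2 to compound 3 (0.70 log units; beyond the scatter). Both steps were modest and ran in opposite directions, so a change of the carbonyl substituent in this series has so far moved this assay by a modest amount either way. For the measured compounds named here, no measured compound carries phenyl directly on the carbonyl, so the direction cannot be read from the data; a modest step is expected, with the number for compound 4 estimated at 3 nM, between 0.8 nM and 12 nM, corresponding to an expected step of a 1.3-fold lower number from compound 3 to compound 4 (0.12 log units; within the scatter).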

Compound 4, half-maximal inhibitory concentration: 400 nM
Beside the measured number, compound 4's estimate is 130-fold (2.12 log units) below it; measured number above the stated range.
By their numbers in this assay, from the lowest: compound 2; then compound 3; then compound 1; then compound 4.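

In this assay, phenyl in place of phenoxymethyl on a carbonyl carbon gave a 100-fold higher number from compound 3 to compound 4 (2.00 log units; beyond the scatter), a step larger than any seen earlier at this position, which shows that this substituent can do far more than shift the number modestly. Phenyl also compares poorly with the two other groups, with a 500-fold higher number from compound 2 to compound 4 (2.70 log units; beyond the scatter) and a 22-fold higher number from compound 1 to compound 4 (1.35 log units; beyond the scatter); compound 4 is thus the weakest inhibitor of the four, and it is the only one whose aromatic ring sits directly on the carbonyl carbon, whereas compound 1, compound 2 and compound 3 all hold that ring through a linker. No available evidence accounts for this loss of inhibition.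

The compounds shown leave open whether the linker itself matters or its particular atoms, which a longer chain such as 2-phenylethyl or a shorter group such as benzyl on the carbonyl could help to separate. They also leave open whether a methyl or methoxy group on the ring of the benzoyl group of compound 4 would change its number, as well as how a simple phenylamino group would compare with the (4-methylphenyl)amino group of compound 2.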